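Compound 4 and the solubility limit

The source may report more compounds than this note shows. Statements on the series, on what has been measured and on what is new or still open speak of the compounds shown alone.

Measured in a physicochemical assay for solubility, in phosphate buffer, at pH 6.8; a lower number here means a less soluble compound, a higher number a more soluble compound:
- compound 1 `CCC(CC)C1C(C(=O)c2ccc(OC)cc2)=C(O)C(=O)N1c1ccc(-c2ccon2)cc1`: 2200 nM
- compound 2 `COc1ccccc1C1C(C(=O)C(C)(C)C)=C(O)C(=O)N1c1ccc(-c2ccsc2)cc1`: 900 nM
- compound 3 `COc1ccccc1C1C(C(=O)C(C)C)=C(O)C(=O)N1c1ccc(-c2ccsc2)cc1`: > 50000 nM, a limit and not a number

Compound 3 sits at the limit of > 50000 nM in this assay, at which 1 of the 3 values shown sits. The change to compound 4 `CC(C)C(=O)C1=C(O)C(=O)N(c2ccc(-c3ccsc3)cc2)C1c1ccccc1OCC[S+](C)[O-]` is a group of 4 heavy atoms (2 carbon, 1 oxygen, 1 sulfur; no ring) in place of a hydrogen atom, on a saturated chain carbon bound to an oxygen on an aromatic ring.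

Going by the values given here, only one measured step is available, an at least 55-fold higher number from compound 2 to compound 3 (1.74 log units; beyond the scatter). It is large, but it lies at a different place, on a saturated chain carbon bound to a carbonyl carbon and two saturated chain carbons, so it gives no direct guide to this change. No change beyond the scatter is therefore expected, a number no higher from compound 3 to compound 4 (the limit leaves the size open). For compound 4 the estimated value is 50000 nM, with an expected range from 15000 nM to 80000 nM.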

Compound 4, solubility: > 50000 nM
Compound 4: no number, only a limit; the forecaster's own chance of this, stated with the estimate: 65%; the middle value lies on the limit itself.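

No step can be read between compound 3 and compound 4, because each value is a limit and not a number: the limit of > 50000 nM in this assay, at which 2 of the 4 values shown sit.

The compounds shown leave open whether this change moves the number at all in this assay.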